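Swapping the Sulfur-Linked Ring in a Hydrazone Series

The compounds below may be only part of what the source reports. "The series", "measured", "known", "first", "only" and "open" are said of these compounds alone.

compound 1 `O=C(CSc1nc2ccccc2s1)N/N=C/c1c[nH]c2ccccc12`: > 80 ug/mL
compound 2 `COc1cc(/C=N/NC(=O)c2ccc(CSc3nc4ccccc4s3)cc2)cc(OC)c1OC`: > 80 ug/mL

In a functional assay on HepG2 cells (Homo sapiens) for inhibition, read by MTT assay, with a stated time of 72 h (a higher number here means a weaker inhibitor, a lower number a stronger inhibitor), compound 1 reaches only the limit of the assay, > 80 ug/mL. Compound 2 likewise gives only a limit, > 80 ug/mL, so no number is known for it. All that is known of compound 2 is the limit of > 80 ug/mL in this assay, at which 2 of the 2 values shown sit. Compound 3 `COc1cc(/C=N/NC(=O)c2ccc(CSc3nc(C)cc(C)n3)cc2)cc(OC)c1OC` differs from compound 2 in one place: 4,6-dimethylpyrimidin-2-yl in place of 1,3-benzothiazol-2-yl on a sulfur. Nothing measured shows how such a change moves this assay, so no step beyond the usual scatter is expected. Compound 3 is therefore expected near 80 ug/mL (range 30 ug/mL to 200 ug/mL), a step of a number no higher from compound 2 to compound 3 (the limit leaves the size open).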

Compound 3, half-maximal inhibitory concentration: 33.3 ug/mL
The estimate for compound 3 lay 2.4-fold (0.38 log units) above the measured number, and the stated range covers the measured number.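

Changing the ring on this sulfur can move the result in this assay: 4,6-dimethylpyrimidin-2-yl in place of 1,3-benzothiazol-2-yl gives an at least 2.4-fold lower number from compound 2 to compound 3 (0.38 log units; beyond the scatter). This position therefore matters, which compounds 1 and 2 could not show, since neither gave a number. The true size of the step stays open because compound 2 gives only a limit: the limit of > 80 ug/mL in this assay, at which 2 of the 3 values shown sit.

As far as these compounds go, whether a plain pyridin-2-yl or a pyrimidin-2-yl without its methyl groups on this sulfur would do the same remains open. So does whether the same swap would lower the number in compound 1.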